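Cyano for fluoro on the benzyl group of compound 2

A few compounds are considered here, and "the series" means these few. Any claim that something is new, unique, unknown or untested is made for them only; others in the source may bear on it.

Measured so far:
compound 1 `COc1ccc([C@@H]2CC(=O)c3c(O)cc(OCc4cn(Cc5cccc(Cl)c5)nn4)cc3O2)cc1O`: 18200 nM
compound 2 `COc1ccc([C@@H]2CC(=O)c3c(O)cc(OCc4cn(Cc5ccccc5F)nn4)cc3O2)cc1O`: 7320 nM

In a functional assay on RAW264.7 cells (Mus musculus) for inhibition, read by Griess assay, with stated times of 2 h and 24 h (a lower number here means a stronger inhibitor, a higher number a weaker inhibitor), compound 2 holds the lowest of the two numbers, with compound 1 the nearest, a 2.5-fold lower number from compound 1 to compound 2 (0.40 log units; beyond the scatter) away. Compound 3 `COc1ccc([C@@H]2CC(=O)c3c(O)cc(OCc4cn(Cc5ccccc5C#N)nn4)cc3O2)cc1O` differs from compound 2 by cyano in place of fluoro on an aromatic carbon. Among the compounds with values here, the only measured step, a 2.5-fold lower number from compound 1 to compound 2 (0.40 log units; beyond the scatter), concerns a different change at the same benzyl group and gives little guidance here. Compound 3 is therefore expected to stay close to compound 2, with a step of a 1.1-fold higher number from compound 2 to compound 3 (0.04 log units; within the scatter) in this assay. The estimate for compound 3 is 8000 nM, within 3000 nM to 22000 nM.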

Compound 3, half-maximal inhibitory concentration: 14600 nM
Estimate against measurement, compound 3: 1.8-fold (0.26 log units) below; the measured number falls inside the stated range.
By their numbers in this assay, from the lowest: compounds 2, 3 and 1 (each within the scatter of the next, the first and the last beyond it).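

The step of a 2.0-fold higher number from compound 2 to compound 3 (0.30 log units; within the scatter) in this assay shows that cyano can replace fluoro at this aromatic carbon without a difference that can be told from the usual scatter. The step of a 1.2-fold lower number from compound 1 to compound 3 (0.10 log units; within the scatter) likewise stays within the scatter, so compound 3 cannot be separated from either compound 1 or compound 2, although those two lie beyond the scatter of each other. No supporting evidence bears on this result. From the compounds shown here alone, whether an amine or a carboxylic acid on this aromatic carbon would read the same remains open.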